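The source may report more compounds than this note shows. Statements on the series, on what has been measured and on what is new or still open speak of the compounds shown alone.

Compound 1 `Cc1ccccc1N1C(=O)/C(=C/c2ccc(OCC(=O)Nc3ccc(C(=O)O)cc3)cc2)SC1=S` in an assay on isolated protein for inhibition of Apoptosis regulator Bcl-2 (Homo sapiens), read by fluorescence polarization (on this read-out lower numbers stand for stronger inhibition and higher numbers for weaker inhibition), gives > 10000 nM; this is a limit of the assay, not a number.
Compound 2 `COc1ccccc1N1C(=O)/C(=C/c2ccc(OCC(=O)Nc3ccc(C(=O)O)cc3)cc2)SC1=S` in this assay gives 10000 nM.
Compound 3 `Cc1ccc(N2C(=O)/C(=C/c3ccc(OCc4ccc(C(=O)O)cc4)cc3)SC2=S)cc1` in this assay gives > 10000 nM; this too is a limit of the assay.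

For the measured compounds named here, the one measured step is a number no higher from compound 1 to compound 2 (the limit leaves the size open), the change being (methoxy in place of methyl on an aromatic carbon). Its size cannot be read, since compound 1 sits at the limit of > 10000 nM in this assay, at which 2 of the 3 values shown sit. Compound 3 shares this core only in part; the difference between the core of compound 1 and the core of compound 3 is not broken down here.

Compound 4 `COc1ccc(N2C(=O)/C(=C/c3ccc(OCc4ccc(C(=O)O)cc4)cc3)SC2=S)cc1` is not yet measured. It stands to compound 3 as compound 2 stands to compound 1: methoxy in place of methyl on an aromatic carbon. The two changes are the same kind of change, not the same, since the group in compound 2 sits ortho to a large group and the group in compound 4 sits para to a large group.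

Going by the values given here, for compound 4 the step that the limit leaves unreadable from compound 3 to compound 4 in this assay is expected to be small, resting on the only measured step of this kind, a number no higher from compound 1 to compound 2 (the limit leaves the size open), which left compound 2 at the edge of the assay. Compound 4 is thus estimated at 12000 nM, with a likely range from 4000 nM to 40000 nM, and a real chance that the assay again reports only a limit.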

Compound 4, inhibition constant: > 10000 nM
Compound 4 was reported as a limit; the forecaster's own chance of this, stated with the estimate: 60%; the middle value lies beyond the limit too.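

Compound 3 and compound 4 are both reported only as limits of the assay in this assay, so no size can be read for the step between them: the limit of > 10000 nM in this assay, at which 3 of the 4 values shown sit.

The compounds shown leave open whether the change from 4-methylphenyl to 4-methoxyphenyl alters inhibition at all, and how far the true values of compound 3 and compound 4 lie beyond the limit.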